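The compounds below may be only part of what the source reports. "The series", "measured", "known", "first", "only" and "open" are said of these compounds alone.

Compound 2, with the structure `COC(=O)C1=C(C)NC(C)=C(C(=O)OCc2cc([N+](=O)[O-])cc([N+](=O)[O-])c2)C1c1cccc([N+](=O)[O-])c1`, carries a 3,5-dinitrophenyl group on the saturated chain carbon bound to an oxygen next to a carbonyl group. In a functional assay on HEK293 cells for antagonist activity at Voltage-dependent L-type calcium channel subunit alpha-1D (Rattus norvegicus), read by FLIPR (a lower number here means a stronger inhibitor, a higher number a weaker inhibitor), compound 2 gives 40 nM. For the measured compounds named here, only one other compound has been measured: compound 1, with the structure `COC(=O)C1=C(C)NC(C)=C(C(=O)OCC2CC2)C1c1cccc([N+](=O)[O-])c1`, which gives 21 nM in this assay. Between these two compounds the change is limited to that same position, and the result was a 1.9-fold higher number from compound 1 to compound 2 (0.28 log units; within the scatter), so the two numbers cannot be told apart.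

Compound 3, with the structure `COC(=O)C1=C(C)NC(C)=C(C(=O)OCc2ccc(OC)cc2)C1c1cccc([N+](=O)[O-])c1`, has not yet been measured. It differs from compound 2 by a change at the same position: 4-methoxyphenyl in place of 3,5-dinitrophenyl on a saturated chain carbon bound to an oxygen next to a carbonyl group. Going by the values given here, the only step that bears on this change is the one from compound 1 to compound 2, which also swapped the group at that position and stayed within the scatter. On that basis no shift beyond the scatter is expected in this assay for compound 3, an expected step of a 1.3-fold lower number from compound 2 to compound 3 (0.12 log units; within the scatter). Compound 3 is therefore estimated at 30 nM in this assay, with a likely range from 8 nM to 120 nM.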

Compound 3, half-maximal inhibitory concentration: 79 nM
The estimate for compound 3 lay 2.6-fold (0.42 log units) below the measured number, within the range that was stated.
By their numbers in this assay, from the lowest: compounds 1, 2 and 3 (each within the scatter of the next, the first and the last beyond it).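

Replacing the 3,5-dinitrophenyl group with 4-methoxyphenyl gives a 2.0-fold higher number from compound 2 to compound 3 (0.30 log units; within the scatter) in this assay, so these two groups cannot be told apart here, even though the group that enters has fewer heavy atoms and fewer hydrogen-bond acceptors. For the compounds shown here, the step from cyclopropyl to 4-methoxyphenyl is the first at this position to go beyond the scatter, with a 3.8-fold higher number from compound 1 to compound 3 (0.58 log units; beyond the scatter), making compound 3 a modestly weaker inhibitor than compound 1, while compound 2 remains within the scatter of both, so the position shows only a small response to these groups. Nothing available explains that step.

The compounds shown leave open whether the gap between compound 1 and compound 3 belongs to the 4-methoxyphenyl group alone or would appear with other groups at this place, since a plain phenyl ring or a longer chain could fall on either side. They also leave open how far the position tolerates a group of a different kind, such as an amine or a carboxylic acid at the end of the chain.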